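Swapping One Saturated Side Chain for Another

The source may report more compounds than this note shows. Statements on the series, on what has been measured and on what is new or still open speak of the compounds shown alone.

Compound 1 `N#Cc1cnc(NCc2cnccc2C(F)(F)F)cc1N[C@H]1CC[C@H](O)CC1` gives 6500 nM in an assay on isolated protein for inhibition of protein kinase C delta type (Homo sapiens), read by TR-FRET, with a stated time of 2 h; a higher number here means a weaker inhibitor, a lower number a stronger inhibitor.
Compound 2 `CO[C@H]1CC[C@H](CNc2cc(NCc3cnccc3C(F)(F)F)ncc2C#N)CC1` reaches only a limit of this assay, > 10000 nM.

Compound 2 therefore has no exact number; it sits at the limit of > 10000 nM in this assay, at which 1 of the 2 values shown sits. Within the data shown here, the one measured step, an at least 1.5-fold higher number from compound 1 to compound 2 (0.18 log units; that floor lies within the scatter), is a floor, and that floor lies within the usual scatter, so the two compounds may well be equally weak.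

Compound 3 `N#Cc1cnc(NCc2cnccc2C(F)(F)F)cc1NCCC1CCOCC1` differs from compound 2 by (oxan-4-yl)methyl in place of 4-methoxycyclohexyl on a saturated chain carbon bound to a nitrogen on an aromatic ring. Among the measured compounds shown here, since the only measured step did not move beyond the scatter, and nothing else here speaks for a gain, compound 3 is expected to stay in the same weak territory: the change from compound 2 to compound 3 is estimated as a step that the limit leaves unreadable from compound 2 to compound 3, with a fair chance that this assay again reports only a limit. The estimate for compound 3 is 12000 nM, expected to fall between 4000 nM and 35000 nM.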

Compound 3, half-maximal inhibitory concentration: > 10000 nM
Compound 3 gave a limit, no number; the forecaster's own chance of this, stated with the estimate: 55%; the middle value does not contradict the limit.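

The change to 2-(oxan-4-yl)ethyl on the nitrogen gives an at least 1.5-fold higher number from compound 1 to compound 3 (0.18 log units; that floor lies within the scatter), so compound 3 may be just as weak as compound 1 in this assay. The step between compound 2 and compound 3 cannot be read, but the result does show that a second kind of side chain, whose six-membered ring holds a hetero atom instead of being carbon only, also gives no exact number. Among the compounds shown, only compound 1 has an exact value, 6500 nM. Compound 2 and compound 3 stop at the limit: the limit of > 10000 nM in this assay, at which 2 of the 3 values shown sit.

From the compounds shown here alone, how far compound 2 and compound 3 really lie from compound 1 stays open, as does whether any side chain here can give a clearly stronger inhibitor. An amine such as piperidin-4-yl or a carboxylic acid on this nitrogen-linked chain would test a kind of group that is absent from these compounds.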